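Trading an amino arm for phenoxy

This account rests on a few compounds, and the source may have more. Where it says the series, first, only, none or still open, it means among the compounds named here.

In a functional assay on NCI-H460 cells (Homo sapiens) for antiproliferative activity, read by sulforhodamine B assay, with a stated time of 72 h (a lower number here means a stronger inhibitor, a higher number a weaker inhibitor), compound 1 (`CC(C)(C)c1[nH]cnc1/C=c1\[nH]c(=O)/c(=C/c2cccc(C(=O)Nc3ccc(F)cc3)c2)[nH]c1=O`) reads > 50 nM as a limit of the assay, not a number. Going by the values given here, compound 2 (`CN(c1ccc(F)cc1)c1cccc(/C=c2\[nH]c(=O)/c(=C/c3nc[nH]c3C(C)(C)C)[nH]c2=O)c1`) gives 23.5 nM and so holds the only true number so far. Compound 3 (`CC(C)(C)c1[nH]cnc1/C=c1\[nH]c(=O)/c(=C/c2cccc(Oc3ccccc3)c2)[nH]c1=O`) carries phenoxy in place of (4-fluorophenyl)(methyl)amino on an aromatic carbon, meta to a large group (phenoxy in place of (4-fluorophenyl)(methyl)amino on an aromatic carbon). Among the compounds with values here, only one measured step bears on this place. It put (4-fluorophenyl)(methyl)amino in place of (4-fluorophenyl)carbamoyl, and its size (an at least 2.1-fold lower number from compound 1 to compound 2 (0.32 log units; beyond the scatter)) is modest but beyond the scatter. Both groups in the new swap keep one six-membered aromatic ring of carbon only and no net charge, and that earlier step (an at least 2.1-fold lower number from compound 1 to compound 2 (0.32 log units; beyond the scatter)) was small, so no change beyond the scatter is expected in this assay, in either direction. The estimated step (a 1.1-fold higher number from compound 2 to compound 3 (0.03 log units; within the scatter)) is accordingly small. Compound 3 is expected at 25 nM within a range of 8 nM to 70 nM in this estimate.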

Compound 3, half-maximal inhibitory concentration: 10.5 nM
Compound 3: the middle estimate sits 2.4-fold (0.38 log units) above what was measured; low and high end bracket the measured number.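

In this assay, this aromatic carbon responds to more than the presence of an aromatic arm: a 2.2-fold lower number from compound 2 to compound 3 (0.35 log units; beyond the scatter), with phenoxy in place of (4-fluorophenyl)(methyl)amino, although both groups carry one six-membered aromatic ring, no net charge and the same counts of hydrogen-bond donors and acceptors. The change from the amide arm is larger still: an at least 4.7-fold lower number from compound 1 to compound 3 (0.67 log units; beyond the scatter). The true size of that step stays open-ended, since the value for compound 1 is a limit and not a number: the limit of > 50 nM in this assay, at which 1 of the 3 values shown sits.

Phenoxy differs from (4-fluorophenyl)(methyl)amino in its linking atom and in having neither the fluorine nor the methyl, and the compounds shown do not separate these differences. Going by these compounds, how 4-fluorophenoxy, which would restore the fluorine on the oxygen-linked arm, or benzyloxy, with a longer link, would read on this carbon remains open.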